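Fluoro step from compound 1 in an adenosine receptor series

This account rests on a few compounds, and the source may have more. Where it says the series, first, only, none or still open, it means among the compounds named here.

Measured in an assay on CHO cells for displacement of a labelled ligand from adenosine receptor A3 (Homo sapiens), read by scintillation counting, with a stated time of 3 h; on this read-out higher numbers stand for weaker inhibition and lower numbers for stronger inhibition:
compound 1 `Cn1cc2c(Cl)nc(NC(=O)c3ccccc3)nc2n1`: 23600 nM
compound 2 `CC(C)(C)Cn1cc2c(Cl)nc(NC(=O)c3ccccc3)nc2n1`: 30300 nM

Compound 1 holds the lowest of the two numbers shown. Going by the values given here, the only measured step, a 1.3-fold higher number from compound 1 to compound 2 (0.11 log units; within the scatter), lies at the saturated chain carbon bound to an aromatic nitrogen and does not touch the phenyl ring. Compound 3 `Cn1cc2c(Cl)nc(NC(=O)c3ccc(F)cc3)nc2n1` differs from compound 1 by fluoro in place of hydrogen on an aromatic carbon, on an aromatic carbon of a six-membered aromatic ring of carbon only, para to a large group. Among the compounds with values here, no measured step bears on this change, so in this assay no step beyond the scatter is expected. Compound 3 is estimated at 22000 nM, between 8000 nM and 55000 nM. The expected step is a 1.1-fold lower number from compound 1 to compound 3 (0.03 log units; within the scatter).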

Compound 3, inhibition constant: 31900 nM
Beside the measured number, compound 3's estimate is 1.5-fold (0.16 log units) below it, within the range that was stated.
By their numbers in this assay, from the lowest: compounds 1, 2 and 3 (each within the scatter of the next).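

The phenyl ring now has its first reading: in this assay, fluoro in place of hydrogen on an aromatic carbon, para to a large group, gives a 1.4-fold higher number from compound 1 to compound 3 (0.13 log units; within the scatter). This single change therefore does not separate compound 3 from compound 1 on this read-out. No evidence is available to explain this result.

From the compounds shown here alone, whether an amine, a carboxylic acid or a methoxy group at this ring carbon would give a step beyond the scatter remains open. Also open, going by these compounds, is how fluoro reads on the tert-butyl-bearing chain of compound 2.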